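The compounds below may be only part of what the source reports. "The series", "measured", "known", "first", "only" and "open" are said of these compounds alone.

Working notes on the series

Compound 1 `Fc1ccc(-c2csc(N/N=C\c3cccs3)n2)cc1` and compound 3 `Fc1ccc(-c2csc(N/N=C\c3cccs3)n2)c(F)c1` differ in one place only, namely (fluoro in place of hydrogen on an aromatic carbon). Compound 2 `Fc1ccc(-c2csc(N/N=C\c3cccc4ccccc34)n2)cc1` carries a different core; how its core differs from the core of compound 1 is not broken down here. Compound 4 `Fc1ccc(-c2csc(N/N=C\c3cccc4ccccc34)n2)c(F)c1` stands to compound 2 as compound 3 stands to compound 1, the difference being (fluoro in place of hydrogen on an aromatic carbon).

In an in vitro assay on BTI-TN-5B1-4 cells for inhibition of Amine oxidase [flavin-containing] A (Homo sapiens), read by Amplex Red, with a stated time of 15 min, tested at 100 uM (on this read-out higher numbers stand for more inhibition at the one concentration tested (going by the name of the read-out) and lower numbers for less inhibition), compound 1 gives 40%. In this assay compound 3 gives 40%, and the step of no change at the digits printed from compound 1 to compound 3 (within the scatter). In this assay compound 2 gives 40%, level with compound 1 and compound 3 within the scatter of repeated measurements.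

The change from compound 2 to compound 4 is the same change as from compound 1 to compound 3: fluoro in place of hydrogen on an aromatic carbon, at a place described in identical words for both pairs, on a six-membered aromatic ring of carbon only, ortho to a large group and meta to a fluoro group. Cut one bond further out, the change reads 4-fluorophenyl to 2,4-difluorophenyl. The change occurs twice among the four compounds, once measured and once not. Among the measured compounds shown here, only one precedent exists, and it sits on the core of compound 1, so the carry-over to the core of compound 2 rests on a single pair.

The step from compound 2 to compound 4 is expected to be no change at the digits printed from compound 2 to compound 4 (within the scatter) because no change at the digits printed from compound 1 to compound 3 (within the scatter) on the core of compound 1. In this assay compound 4 is expected to give about 40%, estimated to lie between 28% and 52%.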

Compound 4, a percentage reported as inhibition, at one concentration (the size of the read-out at that concentration, not a potency): 40%
The estimate for compound 4 equals the measured number at the digits printed; the range from low to high includes it.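

In this assay, the replacement of hydrogen by fluoro on the core of compound 2 gives no change at the digits printed from compound 2 to compound 4 (within the scatter). The change from 4-fluorophenyl to 2,4-difluorophenyl therefore reads the same on both cores in this series, with no gap of note between the two steps: the same change on two cores in this assay, no change at the digits printed (within the scatter) from compound 1 to compound 3 and no change at the digits printed (within the scatter) from compound 2 to compound 4, 0 percentage points apart, within the scatter of two such steps This does not show that the change is neutral in general or that it would carry over to further cores: it rests on two pairs, neither step moves the read-out, and a single-concentration percentage is not a potency, so any difference between the cores that this read-out does not capture remains unseen.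

The compounds shown leave open whether a group other than fluoro at this place on the six-membered aromatic ring, such as chloro, methoxy, an amine or a carboxylic acid, would give a step beyond the scatter on either core. They also leave open whether the agreement between the two steps would hold on a third core, or for a change that does move the read-out on the core of compound 1.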